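Amine in Place of Ester on a Shorter Chain

This account rests on a few compounds, and the source may have more. Where it says the series, first, only, none or still open, it means among the compounds named here.

Compound 1 `NCCCCCCOc1ccc2c(=O)c(-c3ccc(O)cc3)coc2c1` gives >> 9000 nM in an assay (Cricetulus griseus) for inhibition of Monoamine oxidase (Homo sapiens) (on this read-out higher numbers stand for weaker inhibition and lower numbers for stronger inhibition), a limit of the assay.
Compound 2 `CCOC(=O)CCCCCOc1ccc2c(=O)c(-c3ccc(O)cc3)coc2c1` gives 5300 nM in this assay.
Compound 3 `CCOC(=O)CCCCOc1ccc2c(=O)c(-c3ccc(O)cc3)coc2c1` gives > 9000 nM in this assay, a limit of the assay.

Compound 3 therefore stands at a limit rather than at a number, and of the three values shown only compound 2 has a number, the other two sitting at limits the limit of > 9000 nM in this assay, at which 1 of the 3 values shown sits (the limit of >> 9000 nM in this assay, at which 1 of the 3 values shown sits). Compound 4 `NCCCCOc1ccc2c(=O)c(-c3ccc(O)cc3)coc2c1` differs from compound 3 in one place: amino in place of ethoxycarbonyl on a saturated chain carbon, four bonds along the chain from an oxygen on an aromatic ring. For the measured compounds named here, two measured steps bear on this change. The step of an at least 1.6-fold lower number from compound 1 to compound 2 (0.22 log units; that floor lies within the scatter) exchanged an amine for an ester on a longer chain and left the limit, but only by a floor that lies within the scatter. The step of an at least 1.6-fold higher number from compound 2 to compound 3 (0.22 log units; that floor lies within the scatter) returned to a limit on shortening the ester chain, and the step that the two limits leave unreadable from compound 1 to compound 3 cannot be read between its two limits. Compound 4 puts the amine back on the shorter chain, the direction opposite to the step from compound 1 to compound 2, so no drop below the limit is expected and at most a small rise in the number is expected in this assay, a step that the limit leaves unreadable from compound 3 to compound 4. Compound 4 is estimated at 15000 nM, expected within 7000 nM to 60000 nM, most probably reported again as a limit.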

Compound 4, half-maximal inhibitory concentration: > 9000 nM
Compound 4: only a limit was reported; the forecaster's own chance of this, stated with the estimate: 75%; the middle value lies beyond the limit too.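

In this assay, putting amino in place of ethoxycarbonyl on a saturated chain carbon, four bonds along the chain from an oxygen on an aromatic ring, leaves the read-out at a limit, so neither group gives a number on this chain: the limit of > 9000 nM in this assay, at which 2 of the 4 values shown sit. The other two new steps, those from compound 3 and from compound 1 to compound 4, cannot be read, as both ends of each are limits. The one step that can be read is an at least 1.6-fold higher number from compound 2 to compound 4 (0.22 log units; that floor lies within the scatter), so even this step shows no separation beyond the scatter, and compound 2 remains the only compound shown with a number rather than a limit.

On these data alone, it stays open whether any group on this shorter chain would reach a number, for instance a carboxylic acid or a dimethylamino group in place of the amino group, and whether an ester on a longer chain than that of compound 2 would move the number further. As far as these compounds go, how far compound 1, compound 3 and compound 4 lie past their limits also stays open, and with it any order among them.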